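Series notes: benzyl versus phenyl on the imidazole carbon

The source may report more compounds than this note shows. Statements on the series, on what has been measured and on what is new or still open speak of the compounds shown alone.

Compound 2 `O=C(O)c1ccccc1-c1ccc(CCc2ncc(-c3ccccc3)[nH]2)cc1` gives 872 nM in an in vitro functional assay on cells for agonist activity at Bombesin receptor subtype-3 (Mus musculus), read by luminescence and calcium flux (on this read-out higher numbers stand for an effect only at larger amounts of compound and lower numbers for an effect already at smaller amounts), the higher of the two numbers measured; compound 1 `O=C(O)c1ccccc1-c1ccc(CCc2ncc(Cc3ccc(F)cc3)[nH]2)cc1` gives 50 nM. The change to compound 3 `O=C(O)c1ccccc1-c1ccc(CCc2ncc(Cc3cccc(F)c3F)[nH]2)cc1` is 2,3-difluorobenzyl in place of phenyl on an aromatic carbon, next to the ring nitrogen. Going by the values given here, the only step that bears on it runs the other way: a 17-fold higher number from compound 1 to compound 2 (1.24 log units; beyond the scatter), so restoring a benzyl group is expected to lower the number by a comparable margin, an 11-fold lower number from compound 2 to compound 3 (1.04 log units; beyond the scatter). Compound 3 is therefore estimated at 80 nM, with a range of 25 nM to 300 nM.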

Compound 3, half-maximal effective concentration: 8 nM
Compound 3: the middle estimate sits 10-fold (1.00 log units) above what was measured; measured number below the stated range.
By their numbers in this assay, from the lowest: compound 3; then compound 1; then compound 2.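

On the aromatic carbon next to the ring nitrogen, 2,3-difluorobenzyl in place of phenyl gives a 110-fold lower number from compound 2 to compound 3 (2.04 log units; beyond the scatter) in this assay. The position responds not only to benzyl versus phenyl but also to the fluorine pattern on the benzyl ring: 2,3-difluorobenzyl in place of 4-fluorobenzyl gives a 6.3-fold lower number from compound 1 to compound 3 (0.80 log units; beyond the scatter) in this assay. No supporting data accompany these results to account for either step.

The compounds shown leave open how an unsubstituted benzyl group or a longer chain such as phenethyl would compare here. They also do not separate the contributions of the two fluorines in compound 3.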